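The source may hold more compounds than are shown below. What is called first, only, known or untested is meant among the compounds shown, and "the series" means these compounds.

Of the compounds shown here, three of the shared core have been measured in an ADME assay on PC-3 cells (Homo sapiens) for cytotoxicity, read by WST assay, tested at 100 uM; on this read-out lower numbers stand for less inhibition and higher numbers for more inhibition at the one concentration tested (going by the name of the read-out). Compound 1 `Cc1cccc(C(=O)N2CCCC(C(=O)Nc3ccc(Cl)cc3)C2)c1` gives 0% there. Within the data shown here, compound 3 `C=Cc1cccc(C(=O)N2CCCC(C(=O)Nc3ccc(Cl)cc3)C2)c1` gives 0%, and the one recorded step, no change at the digits printed from compound 1 to compound 3 (within the scatter), says that a vinyl in place of methyl on an aromatic carbon moves nothing. Compound 2 `O=C(Nc1cccc(OCCc2ccccn2)c1)C1CCCN(C(=O)c2cc(C(F)(F)F)cc(C(F)(F)F)c2)C1` gives 5% in this assay; its number differs from that of compound 1 and from that of compound 3 by less than the scatter, so the three compounds sit together on this read-out, with no order among them.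

Compound 4 `O=C(Nc1cccc(Oc2nccc(C(F)(F)F)c2Cl)c1)C1CCCN(C(=O)c2cc(C(F)(F)F)cc(C(F)(F)F)c2)C1` is the next member. Its change against compound 2 is 3-chloro-4-(trifluoromethyl)pyridin-2-yl in place of 2-(pyridin-2-yl)ethyl on an oxygen on an aromatic ring. Among the measured compounds shown here, no measured step concerns this oxygen or either pyridinyl group; the only step at hand, from compound 1 to compound 3, is at an aromatic carbon and within the scatter. With all three numbers low and no step beyond the scatter anywhere in the series, the expected step of no change at the digits printed from compound 2 to compound 4 (within the scatter) is none beyond the scatter. Compound 4 is therefore expected to give 5% in this assay, estimated within 0% to 20%.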

Compound 4, a percentage reported as inhibition, at one concentration (the size of the read-out at that concentration, not a potency): 0%
Estimate against measurement, compound 4: 5 percentage points above; measured number inside the range.
By their numbers in this assay, from the lowest: compounds 1, 3, 4 and 2 (each within the scatter of the next).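

At the oxygen on an aromatic ring, 3-chloro-4-(trifluoromethyl)pyridin-2-yl in place of 2-(pyridin-2-yl)ethyl gives a number 5 percentage points lower from compound 2 to compound 4 (within the scatter) in this assay. This is the first step shown at this place, and the earlier step covered only an aromatic carbon; here the whole substituent on the oxygen is exchanged, with the ethyl link gone and chlorine and trifluoromethyl on the pyridine ring, and the read-out stays within the scatter. Nothing measured bears on why this exchange leaves the read-out where it is.

Still open, from the compounds shown here alone, is whether any group on this oxygen, such as an amine, a carboxylic acid or a longer chain, would take the read-out beyond the scatter. The step also does not separate the loss of the ethyl link from the gain of chlorine and trifluoromethyl, so a plain pyridin-2-yl on the same oxygen remains an open case.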